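The compounds below may be only part of what the source reports. "The series", "measured", "known", "first", "only" and "open" are said of these compounds alone.

Measured so far in a functional assay on CHO cells for agonist activity at Free fatty acid receptor 1 (Homo sapiens), read by calcium flux; on this read-out lower numbers stand for an effect already at smaller amounts and higher numbers for an effect only at larger amounts of compound:
- Compound 1 `CO[C@H]1C[C@H](Oc2cc(F)c(F)c(-c3cc(F)c(OCCCC(=O)O)c(F)c3)c2)C1`: compound 1 gives > 100000 nM, which is a limit of the assay, not a number.
- Compound 2 `CO[C@H]1C[C@H](Oc2cc(F)c(F)c(-c3cc(F)c(OCCCCCCC(=O)O)c(F)c3)c2)C1`: compound 2 gives 3500 nM.

Compound 2 therefore stands on the only number shown; the other value is a limit (the limit of > 100000 nM in this assay, at which 1 of the 2 values shown sits). Among the compounds with values here, the one measured step, an at least 28-fold lower number from compound 1 to compound 2 (1.45 log units; beyond the scatter), points the way for compound 3 `CO[C@H]1C[C@H](Oc2cc(F)c(F)c(-c3cc(F)c(OCCCCCCCC(=O)O)c(F)c3)c2)C1`, where the change is carboxymethyl in place of carboxy on a saturated chain carbon, six bonds along the chain from an oxygen on an aromatic ring, the same difference cut one bond further out and smaller. A smaller move in the same direction is expected: a 1.8-fold lower number from compound 2 to compound 3 (0.24 log units; within the scatter). Compound 3 is estimated at 2000 nM, between 700 nM and 8000 nM.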

Compound 3, half-maximal effective concentration: 3480 nM
Estimate against measurement, compound 3: 1.7-fold (0.24 log units) below; measured number inside the range.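

In this assay, carboxymethyl in place of carboxy at this chain position gives a 1.0-fold lower number from compound 2 to compound 3 (0.00 log units; within the scatter), so the effect of lengthening does not carry on from compound 2 to compound 3. The longer acid still holds the whole separation from the short chain, with an at least 28-fold lower number from compound 1 to compound 3 (1.45 log units; beyond the scatter). That separation has an open end, since compound 1 stands at a limit, not a number: the limit of > 100000 nM in this assay, at which 1 of the 3 values shown sits.

On these data alone, whether a still longer chain holds this level or loses it stays open. So does whether a tetrazole in place of the carboxylic acid would keep it.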